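Trimming the Benzyl Substituent Down to a Nitrile

The compounds below may be only part of what the source reports. "The series", "measured", "known", "first", "only" and "open" are said of these compounds alone.

Compound 1, `O=C(N[C@H]1CCCC[C@@H]1O)c1cn(Cc2ccc3ncccc3c2)c2cccnc12`: 87 mL/min/kg
Compound 2, `O=C(N[C@H]1CCCC[C@@H]1O)c1cn(Cc2ccc(-c3cncnc3)cc2)c2cccnc12`: 104 mL/min/kg
Compound 3, `O=C(N[C@H]1CCCC[C@@H]1O)c1cn(Cc2ccc(-n3cc(-c4ccncc4)cn3)cc2)c2cccnc12`: 140 mL/min/kg

These three compounds share one core and differ only in the group carried on the benzyl ring. In an ADME assay on liver for metabolic stability, with Liver microsome (Homo sapiens) as the target, using microsomes (on this read-out lower numbers stand for slow clearance and higher numbers for fast clearance), compound 3 gives the highest of the three numbers, yet its gaps to compound 2 and to compound 1 are within the scatter, so no order among them can be claimed. Among the measured compounds shown here, the single one-change step, a 1.3-fold higher number from compound 2 to compound 3 (0.13 log units; within the scatter), is likewise within the scatter. Compound 4, `N#Cc1ccc(Cn2cc(C(=O)N[C@H]3CCCC[C@@H]3O)c3ncccc32)cc1`, is not yet measured; it differs from compound 3 by cyano in place of 4-(pyridin-4-yl)-1H-pyrazol-1-yl on an aromatic carbon. For the measured compounds named here, no measured step removes a group of that size, so the steps seen give no direction to build on. For compound 4 the step of a 1.6-fold lower number from compound 3 to compound 4 (0.19 log units; within the scatter) is expected to stay within the scatter. Compound 4 is therefore expected to give about 90 mL/min/kg, between 35 mL/min/kg and 200 mL/min/kg.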

Compound 4, clearance: 18 mL/min/kg
Compound 4: middle estimate off by 5.0-fold (0.70 log units), on the high side; measured number below the stated range.
By their numbers in this assay, from the lowest: compound 4; then compounds 1, 2 and 3 (each within the scatter of the next).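

In this assay, cyano on this aromatic carbon gives a real drop, seen in a 7.8-fold lower number from compound 3 to compound 4 (0.89 log units; beyond the scatter) and in a 5.8-fold lower number from compound 2 to compound 4 (0.76 log units; beyond the scatter), both beyond the scatter. Among the compounds shown here, putting 4-cyanophenyl in place of quinolin-6-yl agrees, with a 4.8-fold lower number from compound 1 to compound 4 (0.68 log units; beyond the scatter), so only cyano, the one group here without a ring, stands apart from the others, whose values lie within the scatter of one another. Going by these compounds, whether a single methyl, a chlorine or an amine on this carbon would give an equally low number stays open. Nothing available explains why the number falls.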